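This account rests on a few compounds, and the source may have more. Where it says the series, first, only, none or still open, it means among the compounds named here.

Compound 1 `Cc1cc(N2CC[C@@H](C)[C@@H](N(C)c3ncnc4[nH]ccc34)C2)n2nc(SCc3csc4ccc(Cl)cc34)nc2n1`: > 100000 nM
Compound 2 `Cc1ccc(CSc2nc3nc(C)cc(N4CC[C@@H](C)[C@@H](N(C)c5ncnc6[nH]ccc56)C4)n3n2)cc1`: 82500 nM

Within the data shown here, in a toxicity assay on GES1 cells (Homo sapiens) for inhibition, read by MTT assay, with a stated time of 72 h (a higher number here means a weaker inhibitor, a lower number a stronger inhibitor), compound 2 gives 82500 nM, the only true number so far. Compound 1 gives > 100000 nM, which is a limit of the assay and not a number; see (the limit of > 100000 nM in this assay, at which 1 of the 2 values shown sits).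

Next is compound 3 `Cc1cc(N2CC[C@@H](C)[C@@H](N(C)c3ncnc4[nH]ccc34)C2)n2nc(SCc3ccc([N+](=O)[O-])cc3)nc2n1`, which has nitro in place of methyl on an aromatic carbon, para to a large group: nitro in place of methyl on an aromatic carbon. Among the measured compounds shown here, the aromatic group on the sulfanyl chain therefore changes again, and the only measured step at that part of the series is an at least 1.2-fold lower number from compound 1 to compound 2 (0.08 log units; that floor lies within the scatter). That step has only a floor, and the floor lies within the scatter, so it shows no clear sensitivity to the change. For the measured compounds named here, it also involves a different group swap, and no measured step covers nitro itself. Compound 3 is therefore expected to stay close to compound 2 at 82500 nM in this assay. A reported limit is also possible for compound 3. The estimated change is a 1.2-fold lower number from compound 2 to compound 3 (0.07 log units; within the scatter), expected to lie within the scatter. For compound 3 the estimated value is 70000 nM, with an expected range of 30000 nM to 100000 nM.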

Compound 3, half-maximal inhibitory concentration: 36600 nM
Compound 3: middle estimate off by 1.9-fold (0.28 log units), on the high side, and the stated range covers the measured number.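

Among these compounds, on the aromatic group of the sulfanyl chain, this assay now gives a first step with true numbers at both ends and beyond the scatter: nitro in place of methyl on an aromatic carbon, para to a large group, gives a 2.3-fold lower number from compound 2 to compound 3 (0.35 log units; beyond the scatter) and so shows that this position is not silent, which the earlier floor within the scatter could not show. Set against the 5-chloro-1-benzothiophen-3-yl group, the 4-nitrophenyl group gives an at least 2.7-fold lower number from compound 1 to compound 3 (0.43 log units; beyond the scatter) and this step is a floor only. Compound 1 gives > 100000 nM as a limit of the assay and not a number, so the full size of that step cannot be read: the limit of > 100000 nM in this assay, at which 1 of the 3 values shown sits.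

From the compounds shown here alone, only methyl and nitro are compared at this position on the six-membered aromatic ring, so it stays open whether the lower number belongs to nitro in particular or would also come with an amine, a carboxylic acid or a simple chlorine atom there. Among the compounds shown here, the sulfanyl chain and the shared core are also left open, since a longer chain on the sulfur or any change to the core has no step here.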